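Carboxymethyl on the Chain Carbon of Compound 2

A few compounds are considered here, and "the series" means these few. Any claim that something is new, unique, unknown or untested is made for them only; others in the source may bear on it.

Of the compounds shown here, three have numbers so far in a functional assay (Homo sapiens) for inhibition, with a stated time of 72 h; a lower number here means a stronger inhibitor, a higher number a weaker inhibitor. Compound 1 `COc1cc(C(=O)c2ccc3cc[nH]c3c2)cc(OC)c1OC` gives 452 nM, compound 3 `COc1cc(C(=O)c2ccc3c(ccn3CO)c2)cc(OC)c1OC` gives 35 nM, and compound 2 `COc1cc(C(=O)c2ccc3c(ccn3C)c2)cc(OC)c1OC` gives 12.5 nM. Compound 2 therefore has the lowest number of the three and is the strongest inhibitor among them, clear of both others by more than the scatter.

Compound 4 `COc1cc(C(=O)c2ccc3c(ccn3CCC(=O)O)c2)cc(OC)c1OC` has not yet been measured. It differs from compound 2 by a single change: carboxymethyl in place of hydrogen on a saturated chain carbon bound to an aromatic nitrogen. This places carboxymethyl in place of hydrogen on a saturated chain carbon bound to an aromatic nitrogen, which, cut one bond further out, reads methyl to 2-carboxyethyl.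

Among the measured compounds shown here, one measured step bears on this change, since it acts at the same carbon: hydroxy in place of hydrogen, a 2.8-fold higher number from compound 2 to compound 3 (0.45 log units; beyond the scatter), modest but beyond the scatter. Compound 1 differs from compound 2 in more than one place and offers no guide here. For the measured compounds named here, a single step is thin evidence, and no measured compound yet carries a group like carboxymethyl at this carbon. A move in the same direction is expected, likely larger, with an estimated step of a 24-fold higher number from compound 2 to compound 4 (1.38 log units; beyond the scatter). For compound 4 the expected value is 300 nM, with an estimated range of 50 nM to 2500 nM.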

Compound 4, half-maximal inhibitory concentration: > 10000 nM
Compound 4 was reported as a limit; the forecaster's own chance of this, stated with the estimate: 15%; at least 33-fold (1.52 log units) between middle value and limit.
By their numbers in this assay, from the lowest: compound 2; then compound 3; then compound 1. At a limit, above all of these: compound 4.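

In this assay compound 4 stands only at a limit: the limit of > 10000 nM in this assay, at which 1 of the 4 values shown sits. Among the compounds shown here, this saturated chain carbon bound to an aromatic nitrogen proves far less forgiving than the one earlier step at it suggested: hydroxy in place of hydrogen gave a 2.8-fold higher number from compound 2 to compound 3 (0.45 log units; beyond the scatter), whereas carboxymethyl in place of hydrogen gives an at least 800-fold higher number from compound 2 to compound 4 (2.90 log units; beyond the scatter). Carboxymethyl in place of hydroxy at the same carbon gives an at least 280-fold higher number from compound 3 to compound 4 (2.45 log units; beyond the scatter), so substitution at this carbon as such does not abolish inhibition, as compound 3 shows, and the large loss goes with the identity of the group that enters.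

Carboxymethyl brings a longer chain and a carboxylic acid together, and the compounds shown do not tell which of the two goes with the loss. As far as these compounds go, a propyl chain, a methyl ester or an amine in place of the 2-carboxyethyl group would begin to separate them, and how far inhibition falls with compound 4 stays unknown behind its limit.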